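Epimer of compound 2: expected clearance in microsomes

The source may report more compounds than this note shows. Statements on the series, on what has been measured and on what is new or still open speak of the compounds shown alone.

Compound 2 `COc1cc(C)[nH]c(=O)c1CN1CCc2c(Cl)cc([C@H](O)C3COC3)c(Cl)c2C1=O` and compound 4 `COc1cc(C)[nH]c(=O)c1CN1CCc2c(Cl)cc([C@@H](O)C3COC3)c(Cl)c2C1=O` share one core and differ only at a single stereocentre. In an ADME assay on microsomes from liver (Homo sapiens) for metabolic stability, read by LC-MS, using NADPH, with stated times of 10 min and 45 min, tested at 1 uM (on this read-out lower numbers stand for slow clearance and higher numbers for fast clearance), compound 2 gives < 8 uL/min; this is a limit of the assay, not a number, so compound 2 stands at the floor of the values gathered so far. For the measured compounds named here, compound 1 `COc1cc(C)[nH]c(=O)c1CN1CCc2c(Cl)cc(-c3c(C)noc3C)c(Cl)c2C1=O`, carrying a five-membered aromatic ring on the same aromatic carbon, gives 70 uL/min in this assay, and the step of an at least 8.7-fold lower number from compound 1 to compound 2 (0.94 log units; beyond the scatter) is the only measured step that reaches compound 2. For compound 2 that step runs into (the limit of < 8 uL/min in this assay, at which 1 of the 3 values shown sits), which caps how far it can be measured. Compound 3 `Cc1cc(C)c(CN2CCc3c(Cl)cc([C@H](C)CO)c(Cl)c3C2=O)c(=O)[nH]1`, with a different group on the core, gives 15.8 uL/min in this assay. The change to compound 4 is the two compounds have the same atoms and bonds and differ only in configuration as drawn: 1 of 1 stereo elements differ; a stereocentre at a saturated chain carbon is drawn R in compound 2 and S in compound 4. Going by the values given here, no measured step here compares two compounds differing only in configuration, so the step of an at least 8.7-fold lower number from compound 1 to compound 2 (0.94 log units; beyond the scatter) bears on the neighbourhood of compound 2 but not directly on this change. The expected step that the limit leaves unreadable from compound 2 to compound 4 is therefore none beyond the scatter. Compound 4 is estimated at 6 uL/min, within 2 uL/min to 16 uL/min, and is expected most likely to sit again at the limit.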

Compound 4, intrinsic clearance in a liver preparation (reported as CLH), per the amount of preparation that the assay uses in the liver assay: < 7 uL/min
Compound 4 ended at the assay's limit; the forecaster's own chance of this, stated with the estimate: 60%; the middle value does not contradict the limit.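

In the liver assay, compound 2 and compound 4 both sit at limits of the assay, so the step between them cannot be read and neither configuration at the saturated chain carbon separates from the other. The low clearance also holds in the second configuration of the group with the four-membered non-aromatic ring, with an at least 10-fold lower number from compound 1 to compound 4 (1.00 log units; beyond the scatter). In a physicochemical assay for solubility, measured as kinetic solubility (a higher number here means a more soluble compound, a lower number a less soluble compound), compound 2 gives 234000 nM and compound 4 gives 582000 nM, a gap beyond the scatter that rests on configuration alone: the fact that compounds 2 and 4 differ only in the configuration as drawn

Going by these compounds, how the two configurations compare under their limits in the liver assay stays open. Also open, on these data alone, is whether an amine in place of the hydroxyl group would keep clearance at the limit and preserve the gap seen in the physicochemical assay.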